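This account rests on a few compounds, and the source may have more. Where it says the series, first, only, none or still open, it means among the compounds named here.

Measured so far:
compound 1, `CCOC(=O)COc1c(-c2ccc(OC)cc2)oc2c(CC=C(C)C)c(O)cc(O)c2c1=O`, 30000 nM
compound 2, `COc1ccc(-c2oc3c(CC=C(C)C)c(OC(C(=O)O)C(=O)O)cc(O)c3c(=O)c2OC(C(=O)O)C(=O)O)cc1`, 78900 nM

Both compounds were tested in a functional assay on MDA-MB-435S cells (Homo sapiens) for cytotoxicity, read by MTT assay; on this read-out higher numbers stand for weaker inhibition and lower numbers for stronger inhibition. Compound 1 gives 30000 nM and compound 2 gives 78900 nM, so compound 1 has the lowest number of the two, and the gap between compound 1 and compound 2 lies beyond the scatter. The two compounds differ in more than one place, so nothing about any single structural change can be read from that gap.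

Compound 3, `CCOC(=O)C(C)Oc1c(-c2ccc(OC)cc2)oc2c(CC=C(C)C)c(O)cc(O)c2c1=O`, has not yet been measured in this assay. It differs from compound 1 in one place: methyl in place of hydrogen on a saturated chain carbon bound to a carbonyl carbon and an oxygen on an aromatic ring. For the measured compounds named here, no pair of measured compounds shows this change, so there is no measured step to lean on. Going by the values given here, since compound 1 is the only measured neighbour and the change is a single carbon, the step of a 1.1-fold lower number from compound 1 to compound 3 (0.05 log units; within the scatter) from compound 1 to compound 3 in this assay is expected to be small and to stay within the scatter, with no clear direction. Compound 3 is accordingly expected to give about 27000 nM in this assay, most likely between 10000 nM and 70000 nM.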

Compound 3, half-maximal inhibitory concentration: 4100 nM
For compound 3 the middle estimate is 6.6-fold (0.82 log units) above the measured one, outside the stated range (below it).
By their numbers in this assay, from the lowest: compound 3; then compound 1; then compound 2.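

In this assay the saturated chain carbon bound to a carbonyl carbon and an oxygen on an aromatic ring proves sensitive to a very small change: methyl in place of hydrogen gives a 7.3-fold lower number from compound 1 to compound 3 (0.86 log units; beyond the scatter) and so moves the number beyond the scatter with only one added carbon. For the compounds shown here, this is the first change that can be read in one place, since the earlier pair differed in more than one place and could not be attributed to any single change. It shows that going from (ethoxycarbonyl)methoxy to 1-(ethoxycarbonyl)ethoxy lowers the number on the shared core, although nothing available explains how this step arises.

The compounds shown leave open whether the lower number is specific to methyl on this carbon or would persist or grow with a longer chain such as ethyl or propyl in its place. They also leave open whether the step depends on the ethyl ester, as an amide in place of that ester would show on the same branched chain.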